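Replacing the aromatic ring of compound 1 with pyridin-2-yl

This account rests on a few compounds, and the source may have more. Where it says the series, first, only, none or still open, it means among the compounds named here.

Among the measured compounds shown here, in a functional assay on SW-620 cells (Homo sapiens) for antiproliferative activity, read by MTT assay, with a stated time of 24 h (on this read-out higher numbers stand for weaker inhibition and lower numbers for stronger inhibition), compound 1 `COc1ccc(C(=O)/C=C/c2ccc(N(C)C)cc2)c2c1C=CC(C)(C)O2` gives 570 nM and compound 2 `CCN(CC)c1ccc(/C=C/C(=O)c2ccc(OC)c3c2OC(C)(C)C=C3)cc1` gives 670 nM as the only other number, so neither can be ranked above the other. Compound 3 `COc1ccc(C(=O)/C=C/c2ccccn2)c2c1C=CC(C)(C)O2` carries one change from compound 1: pyridin-2-yl in place of 4-(dimethylamino)phenyl on a double-bonded chain carbon bound to a double-bonded chain carbon. For the measured compounds named here, the one measured step of a 1.2-fold higher number from compound 1 to compound 2 (0.07 log units; within the scatter) lies within the scatter but alters only the amino group, so it is a weak guide to this swap. Going by the values given here, no measured compound lacks that amino group. The step expected in this assay is therefore a 3.5-fold higher number from compound 1 to compound 3 (0.55 log units; beyond the scatter) towards weaker inhibition, a tentative estimate. Compound 3 is expected at 2000 nM (estimated range 500 nM to 8000 nM).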

Compound 3, half-maximal inhibitory concentration: 5000 nM
Estimate against measurement, compound 3: 2.5-fold (0.40 log units) below; measured number inside the range.
By their numbers in this assay, from the lowest: compounds 1 and 2 (each within the scatter of the next); then compound 3.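

In this assay, this position proves sensitive to what it carries: changing dimethylamino to diethylamino left the number within the scatter, but replacing the whole 4-(dimethylamino)phenyl with pyridin-2-yl moves it beyond the scatter, towards weaker inhibition (an 8.8-fold higher number from compound 1 to compound 3 (0.94 log units; beyond the scatter)). No measured evidence explains this loss. The swap changes two things at once, removing the amino group and placing a nitrogen in the ring, and the compounds shown leave open which of them matters. A plain phenyl group or a 4-aminophenyl group at this place would help separate the two.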